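Pyrazoline ureas: sulfonyl replacement at the pendant aryl

The source may hold more compounds than are shown below. What is called first, only, known or untested is meant among the compounds shown, and "the series" means these compounds.

Measured so far:
compound 1 `O=C(Nc1ccc(F)cc1)N1N=C(c2ccc(Br)cc2)CC1c1ccc(F)cc1` gives 16 nM
compound 2 `COCCOc1ccc(C2(CCO)CC(c3ccccc3)=NN2C(=O)Nc2ccc(F)cc2)cc1` gives 60 nM

Both compounds were read in an assay on HEK293 cells for inhibition of Voltage-dependent T-type calcium channel subunit alpha-1H (Homo sapiens), read by FLIPR and calcium flux, with a stated time of 3 min; on this read-out higher numbers stand for weaker inhibition and lower numbers for stronger inhibition. Of the two numbers, compound 2 holds the higher one, and its gap to compound 1 lies beyond the usual scatter, so compound 2 is the weaker inhibitor of the pair. Going by the values given here, compound 1 and compound 2 differ in several places at once, so no single-change step can be drawn between them; their two values are all that can be said.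

Compound 3 `CS(=O)(=O)c1ccc(C2(CCO)CC(c3ccccc3)=NN2C(=O)Nc2ccc(F)cc2)cc1` has not yet been measured in this assay. It differs from compound 2 in one place: methylsulfonyl in place of 2-methoxyethoxy on an aromatic carbon. The remaining structure, including the hydroxyethyl chain and the fluorophenyl urea, is kept.

Among the compounds with values here, no measured pair isolates this change, so there is no step on which to rest a direction. The expectation for compound 3 is a number close to that of compound 2, with the step from a 1.2-fold higher number from compound 2 to compound 3 (0.07 log units; within the scatter) judged as none beyond the scatter. Compound 3 is therefore estimated at 70 nM, within a range from 25 nM to 200 nM.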

Compound 3, half-maximal inhibitory concentration: 420 nM
Compound 3: middle estimate off by 6.0-fold (0.78 log units), on the low side, and the stated range ends below it.
By their numbers in this assay, from the lowest: compound 1; then compound 2; then compound 3.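

In this assay, the change from 4-(2-methoxyethoxy)phenyl to 4-(methylsulfonyl)phenyl gives a 7.0-fold higher number from compound 2 to compound 3 (0.85 log units; beyond the scatter), the only single-change step among the compounds shown. It shows that the substituent on this aromatic carbon, para to a large group, can shift the value beyond the scatter while the hydroxyethyl chain and the fluorophenyl urea stay fixed. The two groups have the same count of hydrogen-bond acceptors and neither has a ring or a net charge, yet the values still separate, and no measurement at hand bears on the reason for this step.

From the compounds shown here alone, with only these two groups compared at this position, it remains open whether the step reflects the arrival of methylsulfonyl, the departure of 2-methoxyethoxy, or both. Going by these compounds, a methoxy group, a dimethylamino group, a carboxylic acid or a longer ether chain on this carbon would help to separate these readings, and whether the step holds on other versions of the core also remains open.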